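The source may report more compounds than this note shows. Statements on the series, on what has been measured and on what is new or still open speak of the compounds shown alone.

Of the compounds shown here, two sharing one core have been measured so far in a functional assay on HCT-15 cells (Homo sapiens) for cytotoxicity, read by ELISA, with a stated time of 2 days; on this read-out higher numbers stand for weaker inhibition and lower numbers for stronger inhibition. Compound 1 `Oc1ccccc1-c1cc(-c2ccccc2)nc(-c2ccco2)c1`, which carries a 2-hydroxyphenyl group, gives 2500 nM. Compound 2 `Oc1cccc(-c2cc(-c3ccccc3)nc(-c3ccco3)c2)c1`, with a 3-hydroxyphenyl group in its place, gives 13900 nM, the higher of the two numbers and so the weaker inhibition. The change is a 5.6-fold higher number from compound 1 to compound 2 (0.75 log units; beyond the scatter).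

The next compound, compound 3 `Oc1ccc(-c2cc(-c3ccccc3)nc(-c3ccco3)c2)cc1`, has the same atoms as compound 2, joined differently: 4-hydroxyphenyl in place of 3-hydroxyphenyl on an aromatic carbon. On the carbon opposite the ring nitrogen, 4-hydroxyphenyl takes the place of 3-hydroxyphenyl. Among the measured compounds shown here, only one measured step bears on this swap, a 5.6-fold higher number from compound 1 to compound 2 (0.75 log units; beyond the scatter). It shows that a similar swap can matter in this assay, but a single step sets no trend and does not reveal where 4-hydroxyphenyl will land. For the measured compounds named here, compound 2 at 13900 nM sits at the high end of the only two numbers available, so a small move downward is the cautious expectation, probably within the scatter. The expected change is a 1.5-fold lower number from compound 2 to compound 3 (0.19 log units; within the scatter). In this assay, compound 3 is expected at about 9000 nM, with an estimated range of 3000 nM to 25000 nM.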

Compound 3, half-maximal inhibitory concentration: 5100 nM
The estimate for compound 3 lay 1.8-fold (0.25 log units) above the measured number; low and high end bracket the measured number.
By their numbers in this assay, from the lowest: compound 1; then compound 3; then compound 2.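

With all three hydroxyphenyl groups now shown on the carbon opposite the ring nitrogen, it is clear that in this assay the number depends on which one sits there, and not in one steady direction: it rises from 2-hydroxyphenyl to 3-hydroxyphenyl, then falls again, with a 2.7-fold lower number from compound 2 to compound 3 (0.44 log units; beyond the scatter) on the way back. 4-hydroxyphenyl does not undo the whole rise, since a 2.0-fold higher number from compound 1 to compound 3 (0.31 log units; beyond the scatter) remains, so among these three compound 1 is the strongest inhibitor and compound 2 the weakest. The groups that swap here have the same atoms and the same counts of hydrogen-bond donors and acceptors, so those counts cannot separate the compounds, and nothing available explains the order.

From the compounds shown here alone, whether the hydroxyl matters at all stays open, and a plain phenyl, a methoxyphenyl or an aminophenyl on the same carbon would address that question. The compounds shown also leave open whether this order would hold if the furan-2-yl or phenyl group of the shared core were replaced, for example by a thiophene or a pyridine.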